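Methyl to Fluoro on the Benzyl Group: an Expected Step

This account rests on a few compounds, and the source may have more. Where it says the series, first, only, none or still open, it means among the compounds named here.

Compound 1 `C=C(Br)C(=O)Nc1ccc(/C=C2\SC(=O)N(Cc3ccc(C)cc3)C2=O)cc1`: 3700 nM
Compound 2 `Nc1ccc(/C=C2\SC(=O)N(Cc3cccc(F)c3)C2=O)cc1`: 116000 nM

Of the compounds shown here, two have been measured in a functional assay on CCRF-CEM cells (Homo sapiens) for cytotoxicity, read by cell counting, with a stated time of 3 days; on this read-out lower numbers stand for stronger inhibition and higher numbers for weaker inhibition. Compound 1 gives 3700 nM, the lowest of the two numbers. Compound 2 gives 116000 nM, a higher number that lies well beyond the usual scatter; since compound 2 differs from compound 1 in more than one place, the two values can only be compared, not broken into a single step.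

Compound 3 `C=C(Br)C(=O)Nc1ccc(/C=C2\SC(=O)N(Cc3ccc(F)cc3)C2=O)cc1` is not yet measured. It differs from compound 1 in one place: fluoro in place of methyl on an aromatic carbon. The rest of the molecule, including the bromoacrylamide and the shared core, is unchanged.

Nothing measured here isolates such a change, so the expectation rests on the small size of the change alone. The step from compound 1 to compound 3 is expected to be small, within the scatter, with no clear direction, which is what a 1.1-fold higher number from compound 1 to compound 3 (0.03 log units; within the scatter) means. For compound 3 in this assay a value of about 4000 nM is expected, with a likely range from 1500 nM to 11000 nM.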

Compound 3, half-maximal inhibitory concentration: 2400 nM
Compound 3: middle estimate off by 1.7-fold (0.22 log units), on the high side; the measured number falls inside the stated range.
By their numbers in this assay, from the lowest: compounds 3 and 1 (each within the scatter of the next); then compound 2.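

In this assay, for the compounds shown here, fluoro in place of methyl gives a 1.5-fold lower number from compound 1 to compound 3 (0.19 log units; within the scatter), the first single change that can be read on its own, and by this step compound 1 and compound 3 cannot be told apart. At this place on the benzyl group, para to a large group, 4-methylbenzyl and 4-fluorobenzyl therefore serve equally well in this assay while the bromoacrylamide and the shared core stay the same, although two groups are too few to show how much this position tolerates in general. Going by these compounds alone, nothing available explains why these two groups give such similar numbers, so the result records only that the swap leaves the read-out within its usual scatter.

As far as these compounds go, whether a quite different group at this place, such as an amine, a carboxylic acid or a longer chain, would move the number beyond the scatter remains open. From the compounds shown here alone, it is also open whether the swap from methyl to fluoro would read the same way with another group in place of the bromoacrylamide.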